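The source may hold more compounds than are shown below. What is called first, only, known or untested is meant among the compounds shown, and "the series" means these compounds.

Working notes on the series.

Compound 1 `Oc1cccc(-c2cc(-c3ccncc3)nc(-c3cccc(Cl)c3)c2)c1` carries a pyridin-4-yl group on the shared core; in a functional assay on HCT-15 cells (Homo sapiens) for cytotoxicity, read by CCK-8 assay and cell counting, with a stated time of 2 days (a higher number here means a weaker inhibitor, a lower number a stronger inhibitor), compound 1 stands at "not determined" (no result reported), so it stands on no number of its own. Among the compounds with values here, the only measured member is compound 2 `Oc1cccc(-c2cc(-c3ccc(Cl)cc3)nc(-c3cccnc3)c2)c1`, which differs from compound 1 in how its groups are arranged around the core; in this assay compound 2 gives 16800 nM, a weak result. Within the data shown here, compound 2 and compound 1 form no single-point pair, so their relation says nothing about the size of any one change.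

Compound 3 `Oc1cccc(-c2cc(-c3cccc(Cl)c3)nc(-c3ccco3)c2)c1` is the next member, not yet measured. It differs from compound 1 in one place: furan-2-yl in place of pyridin-4-yl on an aromatic carbon. With no number for compound 1, the direction and size of this step cannot be anchored; the series as a whole shows only weak inhibition so far, in compound 2. Compound 3 is therefore expected to fall in the same weak range, estimated at 15000 nM, between 4000 nM and 50000 nM, with a real chance that only a limit is reported.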

Compound 3, half-maximal inhibitory concentration: 2460 nM
The estimate for compound 3 lay 6.1-fold (0.79 log units) above the measured number; the measured number lies below the stated range.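

No step can be read from this result: in this assay compound 3 gives 2460 nM, while compound 1 stands at "not determined" (no result reported), so the exchange of pyridin-4-yl for furan-2-yl has no size. The compounds shown leave open what that exchange alone does in this assay. No evidence at hand bears on the result.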